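Series notes: aryl swap on the difluoromethoxy member

This account rests on a few compounds, and the source may have more. Where it says the series, first, only, none or still open, it means among the compounds named here.

Measured so far in an ADME assay on microsomes from liver (Homo sapiens) for metabolic stability; on this read-out lower numbers stand for slow clearance and higher numbers for fast clearance:
- compound 1 `COc1cc([C@](O)(CCN(C)C)[C@@H](c2cc3cc(Br)ccc3nc2OC)c2ccnc(OC)c2OC)cc(OC(C)C)n1`: 6.4 uL/min
- compound 2 `COc1cc([C@](O)(CCN(C)C)[C@@H](c2cc3cc(Br)ccc3nc2OC)c2ccnc(OC)c2OC)cc(OC2CCC2)n1`: 2.5 uL/min
- compound 3 `COc1cc([C@](O)(CCN(C)C)[C@@H](c2cc3cc(Br)ccc3nc2OC)c2cccc(OC)c2F)cc(OC(F)F)n1`: 0.1 uL/min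

Compound 3 stands lowest of the three numbers in this assay; the nearest is compound 2 and the furthest compound 1, both beyond the scatter.

Compound 4 `COc1cc([C@](O)(CCN(C)C)[C@@H](c2cc3cc(Br)ccc3nc2OC)c2ccnc(OC)c2OC)cc(OC(F)F)n1` differs from compound 3 in one place: 2,3-dimethoxypyridin-4-yl in place of 2-fluoro-3-methoxyphenyl on a saturated chain carbon bound to an aromatic carbon and a saturated chain carbon. Among the compounds with values here, no measured pair carries this same change. Within the data shown here, the one measured step, a 2.6-fold lower number from compound 1 to compound 2 (0.41 log units; beyond the scatter), concerns the alkoxy group on the other ring and does not bear on the aryl swap. What can be drawn on is that compounds 1 and 2, which carry the 2,3-dimethoxypyridin-4-yl group, sit well above compound 3, while compound 4 keeps the difluoromethoxy group of compound 3. The step is therefore expected to go upward, beyond the scatter, but probably not the whole way to compound 2.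

Compound 4 is estimated at 1 uL/min, with a range of 0.2 uL/min to 5 uL/min, which means an expected step of a 10-fold higher number from compound 3 to compound 4 (1.00 log units; beyond the scatter).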

Compound 4, intrinsic clearance in a liver preparation (reported as CLH), per the amount of preparation that the assay uses: 2.1 uL/min
Estimate against measurement, compound 4: 2.1-fold (0.32 log units) below; low and high end bracket the measured number.
By their numbers in this assay, from the lowest: compound 3; then compounds 4 and 2 (each within the scatter of the next); then compound 1.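

In this assay the aryl group on the saturated chain carbon emerges as a sensitive position: with the difluoromethoxy group held fixed, 2,3-dimethoxypyridin-4-yl in place of 2-fluoro-3-methoxyphenyl gives a 21-fold higher number from compound 3 to compound 4 (1.32 log units; beyond the scatter) and is a large step. With 2,3-dimethoxypyridin-4-yl held fixed, the group on the oxygen matters less: difluoromethyl gives a 1.2-fold lower number from compound 2 to compound 4 (0.08 log units; within the scatter) against cyclobutyl and a 3.0-fold lower number from compound 1 to compound 4 (0.48 log units; beyond the scatter) against isopropyl in a modest step. No supporting data bear on the cause of the aryl step.

The compounds shown do not separate the ring nitrogen from the fluorine and the second methoxy group as contributors to that step. Also open, on these data alone, are how a plain phenyl group would compare and whether the aryl step keeps its size with isopropyl or cyclobutyl on the oxygen.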